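The compounds below may be only part of what the source reports. "The series", "measured", "known", "first", "only" and "open" are said of these compounds alone.

Values so far in a toxicity assay on HUVEC cells (Homo sapiens) for inhibition; on this read-out lower numbers stand for stronger inhibition of growth and higher numbers for weaker inhibition of growth
compound 1 `COc1cc(OC)cc(N2CCN(C(=O)c3oc(C)nc3-c3ccccc3F)CC2)c1` gives 0.118 ug/mL
compound 2 `Cc1nc(-c2ccccc2)c(C(=O)N2CCN(c3cc(Cl)cc(Cl)c3)CC2)o1` gives 0.191 ug/mL
compound 3 `Cc1nc(-c2cccc(F)c2)c(C(=O)N2CCN(c3cc(Cl)cc(Cl)c3)CC2)o1` gives 0.134 ug/mL

Compound 3 at 0.134 ug/mL lies within the scatter of both compound 1 and compound 2, so these values do not separate. Compound 4 `COc1cc(OC)cc(N2CCN(C(=O)c3oc(C)nc3-c3cccc(F)c3)CC2)c1` differs from compound 3 by 3,5-dimethoxyphenyl in place of 3,5-dichlorophenyl on an amine nitrogen in a ring. Within the data shown here, the only measured step, a 1.4-fold lower number from compound 2 to compound 3 (0.15 log units; within the scatter), is a different change and lies within the scatter, so it bears only weakly on this one. Compound 1 carries the same 3,5-dimethoxyphenyl group, and compound 1 at 0.118 ug/mL is within the scatter of compound 3. No step beyond the scatter is therefore expected in this assay. The estimated step is a 1.0-fold lower number from compound 3 to compound 4 (0.01 log units; within the scatter). For compound 4 the expected value is 0.13 ug/mL, with an estimated range of 0.06 ug/mL to 0.28 ug/mL.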

Compound 4, concentration for 50% growth inhibition: 0.126 ug/mL
Compound 4: middle estimate off by 1.0-fold (0.01 log units), on the high side, within the range that was stated.
By their numbers in this assay, from the lowest: compounds 1, 4, 3 and 2 (each within the scatter of the next).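

In this assay, 3,5-dimethoxyphenyl in place of 3,5-dichlorophenyl on the amine nitrogen gives a 1.1-fold lower number from compound 3 to compound 4 (0.03 log units; within the scatter) and so does not separate the two groups when the shared core carries 3-fluorophenyl. Exchanging 2-fluorophenyl for 3-fluorophenyl gives a 1.1-fold higher number from compound 1 to compound 4 (0.03 log units; within the scatter) and likewise leaves the 3,5-dimethoxyphenyl pair unseparated. No supporting data bear on either result. Still open, on these data alone, is whether a phenyl group carrying a carboxylic acid or an amine at this position would depart from these values.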